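Returning from Naphthyl to a Single Substituted Ring

A few compounds are considered here, and "the series" means these few. Any claim that something is new, unique, unknown or untested is made for them only; others in the source may bear on it.

Of the compounds shown here, three sharing one core have been tested in a functional assay on SW-620 cells (Homo sapiens) for cytotoxicity, read by MTT assay, with a stated time of 72 h; on this read-out higher numbers stand for weaker inhibition and lower numbers for stronger inhibition. Compound 1 `CN(C)c1ccc(/C=C2\S/C(=N\c3nc(-c4ccc(Cl)cc4)cs3)NC2=O)cc1` gives 200 nM, compound 2 `COc1ccc(/C=C2\S/C(=N\c3nc(-c4ccc(Cl)cc4)cs3)NC2=O)cc1` gives 50 nM, and compound 3 `O=C1N/C(=N/c2nc(-c3ccc(Cl)cc3)cs2)S/C1=C\c1ccc2ccccc2c1` gives 20300 nM. On these numbers compound 3 stands highest, and so weakest, of the three: the step of a 100-fold higher number from compound 1 to compound 3 (2.01 log units; beyond the scatter) is large, as is a 410-fold higher number from compound 2 to compound 3 (2.61 log units; beyond the scatter), while a 4.0-fold lower number from compound 1 to compound 2 (0.60 log units; beyond the scatter) is modest. Compound 4 `O=C1N/C(=N/c2nc(-c3ccc(Cl)cc3)cs2)S/C1=C\c1ccc(F)cc1` is not yet measured. It differs from compound 3 by 4-fluorophenyl in place of naphthalen-2-yl on a double-bonded chain carbon bound to a double-bonded ring carbon. The two large steps, a 100-fold higher number from compound 1 to compound 3 (2.01 log units; beyond the scatter) and a 410-fold higher number from compound 2 to compound 3 (2.61 log units; beyond the scatter), both run from a single ring carrying one group at that place to naphthalen-2-yl, and both raise the number greatly; compound 4 moves back to a single ring carrying one group, so a large drop in this assay is expected from compound 3 to compound 4. Fluorine at this place has no measured counterpart, and the modest step of a 4.0-fold lower number from compound 1 to compound 2 (0.60 log units; beyond the scatter) shows that the group on that ring shifts the number somewhat, so the estimate is kept wide. Compound 4 is expected to give about 150 nM, within 30 nM to 1000 nM. The expected step is a 140-fold lower number from compound 3 to compound 4 (2.13 log units; beyond the scatter).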

Compound 4, half-maximal inhibitory concentration: > 50000 nM
Compound 4 was reported as a limit; the forecaster's own chance of this, stated with the estimate: 3%; middle value at least 330-fold (2.52 log units) from the limit.
By their numbers in this assay, from the lowest: compound 2; then compound 1; then compound 3. At a limit, above all of these: compound 4.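

Going by these compounds alone, a single ring carrying one group at this place is not enough on its own: the change to 4-fluorophenyl gives an at least 2.4-fold higher number from compound 3 to compound 4 (0.39 log units; beyond the scatter), so the ring's group counts for more than the earlier compounds suggested. Fluoro in place of methoxy gives an at least 1000-fold higher number from compound 2 to compound 4 (3.00 log units; beyond the scatter), and fluoro in place of dimethylamino gives an at least 250-fold higher number from compound 1 to compound 4 (2.39 log units; beyond the scatter), both far larger than the modest step between those two groups, so the choice of group on this ring can decide nearly everything here. The reading for compound 4 is a limit and not a number, so each of these steps is only a minimum: the limit of > 50000 nM in this assay, at which 1 of the 4 values shown sits.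

On these data alone, how far compound 4 truly lies beyond that limit stays open. Also open, as far as these compounds go, is whether a hydroxy group, an ethoxy group or a chlorine on that ring would behave like methoxy or like fluoro.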